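Dihydropyrimidinethione series: fluoro to methoxy on the aryl ring

This account rests on a few compounds, and the source may have more. Where it says the series, first, only, none or still open, it means among the compounds named here.

Measured so far:
compound 1 `COc1cc(C2=CC(c3ccc(F)cc3)NC(=S)N2)cc(OC)c1OC` — 125 nM
compound 2 `COc1ccc(C2=CC(c3ccc(Br)cc3)NC(=S)N2)cc1` — 126 nM
compound 3 `COc1cccc(C2=NNC(c3ccc(Cl)cc3)C2O)c1` — 49 nM

In a functional assay on MCF7 cells (Homo sapiens) for antiproliferative activity, read by sulforhodamine B assay, with a stated time of 48 h (on this read-out higher numbers stand for weaker inhibition and lower numbers for stronger inhibition), compound 1 gives 125 nM and stands second highest of the three numbers. Compound 2 sits nearest, with a number indistinguishable from compound 1 within the scatter; compound 3 lies furthest, with a lower number beyond the scatter. Among the compounds with values here, no pair of measured compounds differs in one place only, so no measured single step is available.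

Compound 4 `COc1ccc(C2C=C(c3cc(OC)c(OC)c(OC)c3)NC(=S)N2)cc1` is not yet measured. It differs from compound 1 by methoxy in place of fluoro on an aromatic carbon, on an aromatic carbon of a six-membered aromatic ring of carbon only. Compound 2 also carries a methoxy on one aromatic ring and a halogen on the other, and its number matches compound 1 within the scatter, which gives no sign that the exchange moves the read-out much.

For compound 4 the expected step of a 1.2-fold higher number from compound 1 to compound 4 (0.08 log units; within the scatter) is therefore small, in either direction, and likely within the scatter. Compound 4 is estimated at 150 nM, within 60 nM to 400 nM.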

Compound 4, half-maximal inhibitory concentration: 103 nM
Estimate against measurement, compound 4: 1.5-fold (0.16 log units) above; low and high end bracket the measured number.
By their numbers in this assay, from the lowest: compound 3; then compounds 4, 1 and 2 (each within the scatter of the next).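

In this assay, 4-fluorophenyl to 4-methoxyphenyl now stands as a measured single exchange, giving a 1.2-fold lower number from compound 1 to compound 4 (0.08 log units; within the scatter) and lying within the scatter. The position para to a large group therefore tolerates methoxy in place of fluoro in this one pair, although the entering group has the larger heavy-atom count and carries a hydrogen-bond acceptor. No measurement at hand bears on the reason for this outcome.

Going by these compounds, whether the position stays as tolerant with an amine, a carboxylic acid or a longer chain remains open. One pair also cannot show whether methoxy in place of fluoro would give a similar result on a core with a different substitution pattern on its other aromatic ring.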